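Acylated aminomethyl variants on the shared core

The source may hold more compounds than are shown below. What is called first, only, known or untested is meant among the compounds shown, and "the series" means these compounds.

Compound 1 `CCCCc1ccc(CNC(=O)N(C)C)c(=O)n1Cc1ccc(-c2ccccc2-c2nn[nH]n2)cc1` and compound 2 `CCCCc1ccc(CN(C)S(C)(=O)=O)c(=O)n1Cc1ccc(-c2ccccc2-c2nn[nH]n2)cc1` share one core and differ only at the saturated chain carbon bound to an aromatic carbon. Within the data shown here, in a functional assay on the whole organism (artery) for inhibition, with Rattus norvegicus as the target, at a dose of 3 mg/kg by the intraduodenal route (on this read-out higher numbers stand for more inhibition at the one dose given (going by the name of the read-out) and lower numbers for less inhibition), compound 1 gives 28% and compound 2 gives 83.4%; the step of a number 55.4 percentage points higher from compound 1 to compound 2 (beyond the scatter) is the only one measured and puts compound 2 highest of the two numbers. Compound 3 `CCCCc1ccc(CNC(C)=O)c(=O)n1Cc1ccc(-c2ccccc2-c2nn[nH]n2)cc1` returns a hydrogen-bond donor at that place: acetamido in place of methyl(methylsulfonyl)amino on a saturated chain carbon bound to an aromatic carbon. Given that compound 2 carries no donor and compound 1 does, a fall is expected, sized by a number 55.4 percentage points higher from compound 1 to compound 2 (beyond the scatter); the expected step is a number 41.4 percentage points lower from compound 2 to compound 3 (beyond the scatter). Compound 3 is estimated at 42%, within 20% to 65%.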

Compound 3, a percentage reported as inhibition, in the whole organism at one dose (the size of the read-out at that dose, not a potency): 8.6%
For compound 3 the middle estimate is 33.4 percentage points above the measured one; the measured number lies below the stated range.
By their numbers in this assay, from the lowest: compound 3; then compound 1; then compound 2.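

In this assay, acetamido in place of methyl(methylsulfonyl)amino gives a number 74.8 percentage points lower from compound 2 to compound 3 (beyond the scatter) at this place, so both compounds with 1 hydrogen-bond donor here sit well under compound 2. Among those two, the group on the carbonyl carbon also matters: methyl in place of dimethylamino gives a number 19.4 percentage points lower from compound 1 to compound 3 (beyond the scatter) in this series. No evidence on the cause of either step is available.

The compounds shown do not separate the sulfonyl group from the methyl on the nitrogen, as compound 2 alone carries both. Methylsulfonylamino and methyl(acetyl)amino on the same carbon would pull these two changes apart.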